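The source may hold more compounds than are shown below. What is called first, only, known or untested is meant among the compounds shown, and "the series" means these compounds.

Working notes on the series, read in a physicochemical assay for lipophilicity, read by HPLC, measured as chromatographic lipophilicity, at pH 7.4; a higher number here means a more lipophilic compound, a lower number a more polar compound. Going by the values given here, compound 1 (`COc1cccc(NC(=O)c2nnn(Cc3ccc([S+](C)[O-])cc3)c2N)c1`) gives 1.3, the lowest of the three numbers so far. Compound 2 (`COc1cccc(NC(=O)c2nnn(Cc3ccc(C#N)cc3)c2N)c1`) gives 2.3, the nearest to it. Compound 3 (`COc1cccc(NC(=O)c2nnn(C(C)c3ccc(C(C)(C)C)cc3)c2N)c1`) gives 3.9, the furthest, but no one-place comparison with it is available.

The next compound is compound 4 (`COc1cccc(NC(=O)c2nnn(Cc3ccccc3)c2N)c1`). The change is a hydrogen atom in place of a group of 3 heavy atoms (1 carbon, 1 oxygen, 1 sulfur; no ring), on an aromatic carbon, on an aromatic carbon of a six-membered aromatic ring of carbon only, para to a large group.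

Among the compounds with values here, one measured step bears on this change, as it replaces the same group on the same carbon: a number 1.00 log units higher from compound 1 to compound 2 (beyond the scatter). Within the data shown here, no measured step has a hydrogen atom entering, so the size rests on that single comparison. A rise in the same direction, somewhat larger than that step, is expected in this assay. The expected change is a number 1.50 log units higher from compound 1 to compound 4 (beyond the scatter), beyond the scatter. Compound 4 is estimated at 2.8, with an expected range of 2.3 to 3.2.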

Compound 4, distribution coefficient: 2.6
Beside the measured number, compound 4's estimate is 0.20 log units above it; the range from low to high includes it.
By their numbers in this assay, from the lowest: compound 1; then compounds 2 and 4 (each within the scatter of the next); then compound 3.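

In this assay, the group of compound 1 can be taken off this aromatic carbon altogether, leaving only a hydrogen atom (a number 1.30 log units higher from compound 1 to compound 4 (beyond the scatter)), so the rise seen earlier does not depend on a nitrile entering. Hydrogen and cyano cannot be told apart here (a number 0.30 log units higher from compound 2 to compound 4 (within the scatter)), which makes the group of compound 1 the one that stands apart among the three compounds with these substituents, though that holds for compounds 1, 2 and 4 only. Nothing available accounts for this pattern.

Steps to compound 3 cannot be read, since it differs from the others in more than one place. On these data alone, whether an amine or a carboxylic acid on this aromatic carbon would read with compound 1 or with compounds 2 and 4 remains open.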